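This account rests on a few compounds, and the source may have more. Where it says the series, first, only, none or still open, it means among the compounds named here.

Of the compounds shown here, two have so far been measured in a functional assay for inhibition of sodium/hydrogen exchanger (Oryctolagus cuniculus); on this read-out higher numbers stand for weaker inhibition and lower numbers for stronger inhibition: compound 1 `CS(=O)(=O)c1cc(C(=O)N=C(N)N)c(Cl)cc1Cl` gives 140 nM, and compound 2 `COc1cc(Cl)c(C(=O)N=C(N)N)cc1S(C)(=O)=O` gives 40 nM.

Going by the values given here, compound 2 thus stands at the lower of the two numbers, and the single step leading to it, methoxy in place of chloro on an aromatic carbon, gave a 3.5-fold lower number from compound 1 to compound 2 (0.54 log units; beyond the scatter). Compound 3 `CS(=O)(=O)c1cc(C(=O)N=C(N)N)c(Cl)cc1Oc1cccnc1` has not yet been measured. It differs from compound 2 by pyridin-3-yl in place of methyl on an oxygen on an aromatic ring. Among the compounds with values here, no measured step alters the methoxy group itself; the one step known, a 3.5-fold lower number from compound 1 to compound 2 (0.54 log units; beyond the scatter), merely put the methoxy in place of chloro and says nothing about enlarging it into an aryl ether. The expectation for compound 3 in this assay therefore rests on thin ground: a step within or only a little beyond the scatter is expected, with no clear direction. Compound 3 is expected to show a 1.5-fold higher number from compound 2 to compound 3 (0.18 log units; within the scatter). For compound 3 a value near 60 nM is estimated, within a range from 20 nM to 200 nM.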

Compound 3, half-maximal inhibitory concentration: 52 nM
For compound 3 the middle estimate is 1.2-fold (0.06 log units) above the measured one; the range from low to high includes it.
By their numbers in this assay, from the lowest: compounds 2 and 3 (each within the scatter of the next); then compound 1.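

On an oxygen on an aromatic ring, pyridin-3-yl in place of methyl gave a 1.3-fold higher number from compound 2 to compound 3 (0.11 log units; within the scatter) in this assay, so at this place a six-membered aromatic ring reads no differently from a single methyl. Set against chloro on the same aromatic carbon, (pyridin-3-yl)oxy gave a 2.7-fold lower number from compound 1 to compound 3 (0.43 log units; beyond the scatter), and methoxy gave a 3.5-fold lower number from compound 1 to compound 2 (0.54 log units; beyond the scatter); both ether groups therefore lie beyond the scatter from chloro and in the same direction, a pattern that now rests on two groups rather than one. No other measurement bears on these results.

The compounds shown leave open whether the ring nitrogen and its placement matter, a question that phenoxy, pyridin-2-yloxy or pyridin-4-yloxy on the same carbon would address. They also leave open whether the ether oxygen matters, as a secondary amine carrying the same pyridin-3-yl would show, and whether a longer chain such as butoxy would fit the same picture.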